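A Fluoro Swap on a Compound at the Limit

This account rests on a few compounds, and the source may have more. Where it says the series, first, only, none or still open, it means among the compounds named here.

In a functional assay on cells (Neutrophil, Homo sapiens) for inhibition, with a stated time of 10 min (a lower number here means a stronger inhibitor, a higher number a weaker inhibitor), compound 3 (`O=C(c1cnn2c1N(C(=O)Nc1ccccc1)C(c1ccccc1)C2)N1CCCCC1`) gives > 1000 nM as a limit and not a number. Compound 1 (`O=C(Nc1cccc(F)c1)N1c2ccnn2CC1c1ccccc1`) carries a 3-fluorophenyl group and gives > 1000 nM as a limit. Compound 2 (`O=C(NC1CC1)c1cnn2c1N(C(=O)Nc1cccc(F)c1)C(c1ccccc1)C2`) carries the same group and gives > 1000 nM as a limit. The three compounds therefore share the limit of > 1000 nM in this assay, at which 3 of the 3 values shown sit, and cannot be ranked against one another.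

Compound 4 (`O=C(c1cnn2c1N(C(=O)Nc1cccc(F)c1)C(c1ccccc1)C2)N1CCCCC1`) is compound 3 with fluoro in place of hydrogen on an aromatic carbon. The difference reads fluoro in place of hydrogen on an aromatic carbon and turns phenylcarbamoyl to (3-fluorophenyl)carbamoyl.

Going by the values given here, the only measured step is a step that the two limits leave unreadable from compound 1 to compound 2 and it is a different change, so no measured step tests this swap or gives it a size. With fluoro present, compound 2 still gives > 1000 nM as a limit, so no gain in strength is expected. The expected step is a step that the limit leaves unreadable from compound 3 to compound 4 and its direction is uncertain. Compound 4 is estimated at 2000 nM with an expected range from 500 nM to 10000 nM in this measurement.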

Compound 4, half-maximal inhibitory concentration: 1.2 nM
Beside the measured number, compound 4's estimate is 1700-fold (3.22 log units) above it; the whole stated range lies above it.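

In this assay, the swap from phenyl to 3-fluorophenyl gives an at least 830-fold lower number from compound 3 to compound 4 (2.92 log units; beyond the scatter), so fluoro on this aromatic carbon can separate a compound at the limit from a strong inhibitor. Fluoro does not do this alone, as the group on the carbonyl carbon also counts, with an at least 830-fold lower number from compound 2 to compound 4 (2.92 log units; beyond the scatter), and the whole (piperidin-1-yl)carbonyl group counts too, with an at least 830-fold lower number from compound 1 to compound 4 (2.92 log units; beyond the scatter). In these compounds, the strength appears only where 3-fluorophenyl and piperidin-1-yl stand together, something the earlier compounds could not show, as they cannot be ranked against one another: the limit of > 1000 nM in this assay, at which 3 of the 4 values shown sit.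

The compounds shown leave open whether chloro or methoxy in place of the fluoro would keep this strength. They also leave open whether morpholine or dimethylamino could stand in for piperidin-1-yl on the carbonyl carbon.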